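The source may report more compounds than this note shows. Statements on the series, on what has been measured and on what is new or still open speak of the compounds shown alone.

Three compounds have been measured in a functional assay on aorta (strain Wistar) for inhibition, with Thoracic aorta (Rattus norvegicus) as the target; a lower number here means a stronger inhibitor, a higher number a weaker inhibitor:

Compound 1 `COc1ccc(-c2cc(-c3cc4ccccc4o3)nc(OC)c2C#N)c(OC)c1` gives 425000 nM.
Compound 2 `CCOc1nc(-c2cc3ccccc3o2)cc(-c2ccc(OC)cc2OC)c1C#N` gives 488000 nM.
Compound 3 `COc1nc(-c2cc3ccccc3o2)cc(-c2cn(C)c3ccccc23)c1C#N` gives 262000 nM.

Compound 1 and compound 2 differ only by methyl in place of hydrogen on a saturated chain carbon bound to an oxygen on an aromatic ring, and that change made a step of a 1.1-fold higher number from compound 1 to compound 2 (0.06 log units; within the scatter). Compound 3 has a different core from compound 1; the difference between the two cores is not broken down here. The unmeasured compound 4 `CCn1cc(-c2cc(-c3cc4ccccc4o3)nc(OC)c2C#N)c2ccccc21` differs from compound 3 by methyl in place of hydrogen on a saturated chain carbon bound to an aromatic nitrogen. The place is not the same: in the earlier pair the chain carbon is bound to an oxygen on an aromatic ring, here it is bound to an aromatic nitrogen, so this is the same kind of change, not the same change. Given the size of a 1.1-fold higher number from compound 1 to compound 2 (0.06 log units; within the scatter), only a small step is expected, estimated at a 1.1-fold higher number from compound 3 to compound 4 (0.03 log units; within the scatter). Compound 4 is therefore expected to give about 280000 nM in this assay, between 130000 nM and 600000 nM.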

Compound 4, half-maximal inhibitory concentration: 299000 nM
Beside the measured number, compound 4's estimate is 1.1-fold (0.03 log units) below it, within the range that was stated.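

In this assay, putting methyl in place of hydrogen on the saturated chain carbon bound to an aromatic nitrogen made a step of a 1.1-fold higher number from compound 3 to compound 4 (0.06 log units; within the scatter). The earlier step sat on a chain carbon bound to an oxygen on an aromatic ring, yet the two steps agree: the same change on two cores in this assay, a 1.1-fold higher number (0.06 log units; within the scatter) from compound 1 to compound 2 and a 1.1-fold higher number (0.06 log units; within the scatter) from compound 3 to compound 4, 1.0-fold (0.00 log units) apart, within the scatter of two such steps

This shows that, on these two cores, lengthening methyl to ethyl left the number within the scatter, but it does not show a rule for other cores, since two small steps cannot reveal any real effect of the added methyl.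

Still open, as far as these compounds go, is whether a longer chain, such as butyl, or a chain ending in an amine would move the number beyond the scatter at either place.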